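The compounds below may be only part of what the source reports. "The series", "measured", "known", "first", "only" and "open" are said of these compounds alone.

Measured so far:
compound 1 `Cc1cc(C)c(NC(=O)c2sccc2S(=O)(=O)Nc2onc(C)c2Cl)c(Cl)c1` - 2.6 h
compound 2 `Cc1cc(C)c(NC(=O)c2sccc2S(=O)(=O)Nc2onc(C)c2Cl)c(C(=O)c2ccccc2)c1` - 3.95 h

In an ADME assay on the whole organism for pharmacokinetics, with Rattus norvegicus as the target (a lower number here means that the compound disappears faster, a higher number that the compound lasts longer), compound 1 has a single measured neighbour in compound 2 and the step between them is a 1.5-fold higher number from compound 1 to compound 2 (0.18 log units; within the scatter) so the two cannot be told apart. Still unmeasured is compound 3 `Cc1cc(C)c(NC(=O)c2sccc2S(=O)(=O)Nc2onc(C)c2Cl)c(C(=O)CS(C)(=O)=O)c1` with the change ((methylsulfonyl)methyl)carbonyl in place of chloro on an aromatic carbon in which ((methylsulfonyl)methyl)carbonyl stands in place of chloro on an aromatic carbon.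

Among the compounds with values here, only one measured step bears on this change: a 1.5-fold higher number from compound 1 to compound 2 (0.18 log units; within the scatter) with benzoyl in place of chloro on an aromatic carbon. Within the data shown here, that entering group also begins with a carbonyl but holds a ring, and no measured compound carries a methylsulfonyl group, so the step is only a weak guide. In this assay no step beyond the scatter is expected in either direction, and the range has to stay wide. The expected step is a 1.2-fold higher number from compound 1 to compound 3 (0.06 log units; within the scatter) as a working estimate. For compound 3 the estimated half-life is 3 h with an expected range from 1.3 h to 6.5 h for now.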

Compound 3, half-life: 12.2 h
Compound 3: middle estimate off by 4.1-fold (0.61 log units), on the low side; measured number above the stated range.
By their numbers in this assay, from the lowest: compounds 1 and 2 (each within the scatter of the next); then compound 3.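

In this assay this position, the aromatic carbon ortho to a large group, responds to the change: ((methylsulfonyl)methyl)carbonyl in place of chloro gives a 4.7-fold higher number from compound 1 to compound 3 (0.67 log units; beyond the scatter) and so moves the number beyond the scatter, which the benzoyl group of compound 2 did not do. With the carbonyl kept on this carbon, (methylsulfonyl)methyl in place of phenyl gives a 3.1-fold higher number from compound 2 to compound 3 (0.49 log units; beyond the scatter) and shows that the group on the carbonyl carbon matters in this set of three, with compound 2 going against any reading that a carbonyl alone raises the number. Nothing at hand explains the longer half-life of compound 3.

The compounds shown do not separate the part played by the carbonyl from that of the methylsulfonyl group, so a methylsulfonyl group placed directly on the aromatic carbon or a longer chain between the carbonyl and the methylsulfonyl group could each read differently. Going by these compounds, it also remains open whether an amine or a carboxylic acid on the carbonyl carbon would follow compound 3 or stay with compound 1 and compound 2.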